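Methyl in place of hydrogen on compound 3

The source may report more compounds than this note shows. Statements on the series, on what has been measured and on what is new or still open speak of the compounds shown alone.

In a functional assay on FM3A cells (Mus musculus), with a stated time of 2 days (a higher number here means a weaker inhibitor, a lower number a stronger inhibitor), compound 1 `O=C(Nc1ccn([C@H]2OCC=CC2=O)c(=O)n1)c1ccccc1` gives 62000 nM. Compound 2 `C=C1C=CCO[C@@H]1n1ccc(NC(=O)c2ccccc2)nc1=O` gives 379000 nM. Within the data shown here, the one measured step is a 6.1-fold higher number from compound 1 to compound 2 (0.79 log units; beyond the scatter). It swaps the group on an aromatic nitrogen, so it sets no size for the change considered here. Compound 3 `C=C1[C@H](O)[C@H](O)CO[C@@H]1n1ccc(O)nc1=O` reports only a limit, > 800000 nM. That places compound 3 at the limit of > 800000 nM in this assay, at which 1 of the 3 values shown sits, with no number to start from. Compound 4 `C=C1[C@H](O)[C@H](O)CO[C@@H]1n1cc(C)c(O)nc1=O` differs from compound 3 by methyl in place of hydrogen on an aromatic carbon. No step beyond the scatter is expected in this assay, and the estimated step is a number no higher from compound 3 to compound 4 (the limit leaves the size open). Compound 4 is expected near 800000 nM, with an estimated range of 300000 nM to 1600000 nM.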

Compound 4, half-maximal inhibitory concentration: 775000 nM
The estimate for compound 4 lay 1.0-fold (0.01 log units) above the measured number; measured number inside the range.
By their numbers in this assay, from the lowest: compound 1; then compound 2; then compound 4. At a limit, above all of these: compound 3.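

In this assay, methyl in place of hydrogen on this aromatic carbon, ortho to a hydroxy group, gives an at least 1.0-fold lower number from compound 3 to compound 4 (0.01 log units; that floor lies within the scatter). Compound 4 therefore supplies the first measured number for this core with methyl at this position, 775000 nM, yet no change beyond the scatter is shown. Compound 3 stands only at a limit, so the true size of the step stays open: the limit of > 800000 nM in this assay, at which 1 of the 4 values shown sits.

Going by these compounds, it remains open whether an ethyl group, a chlorine atom or an amine on this carbon would move the number. Also open, on these data alone, is whether methyl here would have any effect on the core of compound 1.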